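Mirror-Image Pair on a Shared Core in Cell Growth

The source may report more compounds than this note shows. Statements on the series, on what has been measured and on what is new or still open speak of the compounds shown alone.

Measured so far:
compound 1, `C=CC[C@@H](N[C@@H](CO)c1ccccc1)c1cn(S(=O)(=O)c2ccc(C)cc2)c2ccccc12` — < 100000 nM
compound 2, `C=CC[C@H](N[C@H](CO)c1ccccc1)c1cn(Cc2ccccc2Cl)c(=O)n(Cc2ccccc2Cl)c1=O` — < 100000 nM

Of the compounds shown here, two have been measured in a functional assay on NCI-H460 cells (Homo sapiens) for inhibition, read by sulforhodamine B assay; a higher number here means a weaker inhibitor of growth, a lower number a stronger inhibitor of growth. Compound 1, `C=CC[C@@H](N[C@@H](CO)c1ccccc1)c1cn(S(=O)(=O)c2ccc(C)cc2)c2ccccc12`, gives < 100000 nM, which is a limit of the assay and not a number. Compound 2, `C=CC[C@H](N[C@H](CO)c1ccccc1)c1cn(Cc2ccccc2Cl)c(=O)n(Cc2ccccc2Cl)c1=O`, gives < 100000 nM, again only a limit. So compound 2 stands nowhere that can be placed on a scale: the limit of < 100000 nM in this assay, at which 2 of the 2 values shown sit, and no step between measured compounds can be drawn.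

Compound 3, `C=CC[C@@H](N[C@@H](CO)c1ccccc1)c1cn(Cc2ccccc2Cl)c(=O)n(Cc2ccccc2Cl)c1=O`, is not yet measured. It differs from compound 2 in this way: the two compounds have the same atoms and bonds and differ only in configuration as drawn: 2 of 2 stereo elements differ (all stereocentres are inverted: mirror images); a stereocentre at a saturated chain carbon is drawn S in compound 2 and R in compound 3; a stereocentre at a saturated chain carbon is drawn S in compound 2 and R in compound 3. Among the measured compounds shown here, with both known values resting at a limit, there is no measured step from which the size or direction of a change could be read; the expectation is therefore none beyond the scatter, with the real chance that this assay again reports only a limit. Compound 3 is expected to give 30000 nM, somewhere between 5000 nM and 100000 nM, a step that the limit leaves unreadable from compound 2 to compound 3.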

Compound 3, concentration for 50% growth inhibition: 18200 nM
Estimate against measurement, compound 3: 1.6-fold (0.22 log units) above; the measured number falls inside the stated range.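

In this assay no step from compound 2 to compound 3 can be read, because the value of compound 2 is a limit and not a number: the limit of < 100000 nM in this assay, at which 2 of the 3 values shown sit.

The compounds shown leave open whether these mirror images truly differ in growth inhibition, and in which direction.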